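The source may hold more compounds than are shown below. What is called first, only, known or untested is meant among the compounds shown, and "the series" means these compounds.

Three compounds share one core and differ only in the aryl group attached to the carbonyl carbon. Compound 1 `COc1cc(-c2nnc3n2NC(c2ccco2)C(C(=O)c2cccc(Br)c2)S3)cc(OC)c1OC` gives 63900 nM in a functional assay on PC-3 cells (Homo sapiens) for cytotoxicity, read by MTT assay, with a stated time of 48 h; on this read-out lower numbers stand for stronger inhibition and higher numbers for weaker inhibition. Compound 2 `COc1cc(-c2nnc3n2NC(c2ccco2)C(C(=O)c2ccc(C)cc2)S3)cc(OC)c1OC` gives 7500 nM in this assay, and compound 3 `COc1cc(-c2nnc3n2NC(c2ccco2)C(C(=O)c2ccc(-c4ccccc4)cc2)S3)cc(OC)c1OC` gives 45900 nM. Compound 2 stands lowest of the three: the step of an 8.5-fold lower number from compound 1 to compound 2 (0.93 log units; beyond the scatter) and the step of a 6.1-fold higher number from compound 2 to compound 3 (0.79 log units; beyond the scatter) both lie beyond the scatter, so compound 2 is the most potent compound measured here, while the step of a 1.4-fold lower number from compound 1 to compound 3 (0.14 log units; within the scatter) lies within the scatter. Compound 4 `COc1cc(-c2nnc3n2NC(c2ccco2)C(C(=O)c2ccc([N+](=O)[O-])cc2)S3)cc(OC)c1OC` has not yet been measured; it differs from compound 2 by nitro in place of methyl on an aromatic carbon. Both measured steps bear on this change, since each alters the same aryl group on the carbonyl carbon: moving away from 4-methylphenyl in either direction brought a modest loss in this assay. Nitro is a third departure from methyl, so a modest rise is expected rather than a gain. Compound 4 is therefore expected to give 25000 nM, within a range from 8000 nM to 80000 nM. The expected step of a 3.3-fold higher number from compound 2 to compound 4 (0.52 log units; beyond the scatter) would echo the earlier losses.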

Compound 4, half-maximal inhibitory concentration: 27900 nM
The estimate for compound 4 lay 1.1-fold (0.05 log units) below the measured number, within the range that was stated.
By their numbers in this assay, from the lowest: compound 2; then compounds 4, 3 and 1 (each within the scatter of the next, the first and the last beyond it).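

Nitro on the aromatic carbon para to a large group joins the departures from methyl that raise the number in this assay: a 3.7-fold higher number from compound 2 to compound 4 (0.57 log units; beyond the scatter). Among the four compounds, every aryl group tried in place of 4-methylphenyl therefore gives a higher number, and none goes against this. Nitro and phenyl at this position cannot be told apart, as a 1.6-fold lower number from compound 3 to compound 4 (0.22 log units; within the scatter) shows, yet 4-nitrophenyl does separate from 3-bromophenyl with a 2.3-fold lower number from compound 1 to compound 4 (0.36 log units; beyond the scatter), which 4-phenylphenyl did not do.

The compounds shown leave open whether an amine, a carboxylic acid or a longer chain at this position would match compound 2 at 7500 nM. No evidence at hand accounts for why methyl stands apart from the other groups at this position.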